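Moving the methoxy group on the pendant aryl of compound 3

The source may hold more compounds than are shown below. What is called first, only, known or untested is meant among the compounds shown, and "the series" means these compounds.

Compound 3 `COc1cccc(-c2c(S(=O)(=O)c3ccc(C)c(C)c3)cnc3cc(F)ccc23)c1` carries a 3-methoxyphenyl on the shared core and a dimethylphenyl on the sulfonyl sulfur. In an ADME assay on microsomes from liver (Homo sapiens) for metabolic stability, tested at 2.5 uM (on this read-out higher numbers stand for fast clearance and lower numbers for slow clearance), compound 3 gives 8.78 mL/min, the highest of the three numbers measured, and its gaps to the other two compounds lie beyond the usual scatter. Compound 1 `COc1ccc(-c2c(S(=O)(=O)c3cccc(F)c3)cnc3cc(F)ccc23)cc1` gives 1.89 mL/min and compound 2 `COc1ccc(-c2c(S(=O)(=O)c3ccc(OC)cc3)cnc3cc(F)ccc23)cc1` gives 1.18 mL/min; between them, a 1.6-fold lower number from compound 1 to compound 2 (0.20 log units; within the scatter), which concerns the sulfonyl aryl only.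

Compound 4 `COc1ccc(-c2c(S(=O)(=O)c3ccc(C)c(C)c3)cnc3cc(F)ccc23)cc1` differs from compound 3 in one place: 4-methoxyphenyl in place of 3-methoxyphenyl on an aromatic carbon. Among the measured compounds shown here, no measured step tests this change on its own. Compounds 1 and 2 share the 4-methoxyphenyl of compound 4 but also carry other sulfonyl aryls, so their lower values cannot be attributed to that group alone. The dimethylphenyl sulfonyl, present only in compound 3, remains in compound 4. On this basis the expectation is a modest fall, a 1.6-fold lower number from compound 3 to compound 4 (0.20 log units; within the scatter), with wide uncertainty. Compound 4 is estimated at 5.5 mL/min, within a range of 2 mL/min to 12 mL/min.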

Compound 4, intrinsic clearance in a liver preparation (reported as CLH), per the amount of preparation that the assay uses: 4.13 mL/min
Compound 4: middle estimate off by 1.3-fold (0.12 log units), on the high side; measured number inside the range.
By their numbers in this assay, from the lowest: compounds 2 and 1 (each within the scatter of the next); then compound 4; then compound 3.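

In this assay, the change from 3-methoxyphenyl to 4-methoxyphenyl on the aromatic carbon opposite the ring nitrogen can now be read on its own, with 3,4-dimethylphenyl kept on the sulfonyl sulfur: a 2.1-fold lower number from compound 3 to compound 4 (0.33 log units; beyond the scatter). With 4-methoxyphenyl kept on the shared core, the sulfonyl aryl also matters, as the steps of a 3.5-fold higher number from compound 2 to compound 4 (0.54 log units; beyond the scatter) and a 2.2-fold higher number from compound 1 to compound 4 (0.34 log units; beyond the scatter) both point upward with 3,4-dimethylphenyl. The compounds shown come with no data that explain either change.

From the compounds shown here alone, the methoxy move is tested with only one sulfonyl aryl, so it remains open whether it gives a similar step with 3-fluorophenyl or 4-methoxyphenyl on the sulfur. Also open, going by these compounds, is how this assay responds when an amine or a carboxylic acid replaces the methoxy on the pendant aryl.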